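Coumarin-pyrazoline amides: swapping the amine on the acetyl chain

The compounds below may be only part of what the source reports. "The series", "measured", "known", "first", "only" and "open" are said of these compounds alone.

Compound 1 `O=C(c1ccccc1)N1N=C(c2cc3ccccc3oc2=O)CC1c1ccccc1` in a functional assay on PC-3 cells (Homo sapiens) for cytotoxicity, read by MTT assay, with a stated time of 48 h (on this read-out lower numbers stand for stronger inhibition and higher numbers for weaker inhibition), gives 5870 nM.
Compound 2 `O=C(CNC1CC1)N1N=C(c2cc3ccccc3oc2=O)CC1c1ccccc1` in this assay gives 28500 nM.
Compound 3 `CC1CCCCN1CC(=O)N1N=C(c2cc3ccccc3oc2=O)CC1c1ccccc1` in this assay gives 36300 nM.

Compound 3 carries the highest number of the three; its gap to compound 2 is within the scatter, while the step of a 6.2-fold higher number from compound 1 to compound 3 (0.79 log units; beyond the scatter) is beyond it, as is a 4.9-fold higher number from compound 1 to compound 2 (0.69 log units; beyond the scatter).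

Compound 4 `CN1CCN(CC(=O)N2N=C(c3cc4ccccc4oc3=O)CC2c2ccccc2)CC1` differs from compound 3 by 4-methylpiperazin-1-yl in place of 2-methylpiperidin-1-yl on a saturated chain carbon bound to a carbonyl carbon. Among the measured compounds shown here, the only step that bears directly on this change is the exchange of one amine for another on the same chain carbon, a 1.3-fold higher number from compound 2 to compound 3 (0.11 log units; within the scatter), which stayed within the scatter. On that basis the step from compound 3 to compound 4 is expected to be a 1.0-fold lower number from compound 3 to compound 4 (0.02 log units; within the scatter), not beyond the scatter. Compound 4 is therefore estimated at 35000 nM in this assay, with a range of 12000 nM to 90000 nM.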

Compound 4, half-maximal inhibitory concentration: 25800 nM
Compound 4: middle estimate off by 1.4-fold (0.13 log units), on the high side; the measured number falls inside the stated range.
By their numbers in this assay, from the lowest: compound 1; then compounds 4, 2 and 3 (each within the scatter of the next).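

In this assay, 4-methylpiperazin-1-yl in place of 2-methylpiperidin-1-yl on a saturated chain carbon bound to a carbonyl carbon gives (a 1.4-fold lower number from compound 3 to compound 4 (0.15 log units; within the scatter)), and in place of cyclopropylamino gives (a 1.1-fold lower number from compound 2 to compound 4 (0.04 log units; within the scatter)). A second ring nitrogen therefore separates neither pair, and all three amines at this place now lie within the scatter of one another. The step from phenyl stays beyond the scatter with this amine as well (a 4.4-fold higher number from compound 1 to compound 4 (0.64 log units; beyond the scatter)), and no compound shown goes against that.

As far as these compounds go, whether a morpholine ring or a longer chain between the carbonyl and the amine would leave the number in this range remains open. Nothing on hand accounts for any of these steps.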